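A few compounds are considered here, and "the series" means these few. Any claim that something is new, unique, unknown or untested is made for them only; others in the source may bear on it.

Compound 1, with the structure `Cc1c(OCCCCOc2ccc(C(=O)CC(C)(C)C)c(O)c2C)cccc1C(=O)O`, was tested in an assay on HEK293 cells for positive allosteric modulation of metabotropic glutamate receptor 3 (Rattus norvegicus), read by thallium flux, with a stated time of 2.5 min (on this read-out higher numbers stand for larger maximal responses and lower numbers for smaller maximal responses), where compound 1 reaches 109%. Compound 2, built on a different core, has the structure `COc1cc(C(=O)O)ccc1OCCCCOc1ccc(C(=O)CC(C)(C)C)c(O)c1C`; in this assay compound 2 gives 109%, so the two values sit level with each other and together stand highest among the three measured numbers. How the core of compound 1 and the core of compound 2 differ is not broken down here.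

Compound 3 has the structure `CC(=O)c1ccc(OCCCCOc2cccc(C(=O)O)c2C)c(C)c1O` and differs from compound 1 only by hydrogen in place of tert-butyl on a saturated chain carbon bound to a carbonyl carbon. In this assay compound 3 reaches 17.1%, and the step is a number 91.9 percentage points lower from compound 1 to compound 3 (beyond the scatter), a loss far beyond the usual scatter of the assay.

Compound 4, with the structure `COc1cc(C(=O)O)ccc1OCCCCOc1ccc(C(C)=O)c(O)c1C`, is the not yet measured counterpart on the core of compound 2. It differs from compound 2 by hydrogen in place of tert-butyl on a saturated chain carbon bound to a carbonyl carbon, the same change, at the same place, that turns compound 1 into compound 3. Within the data shown here, since the only precedent for this change is a number 91.9 percentage points lower from compound 1 to compound 3 (beyond the scatter), and since compound 2 starts from 109%, a comparably large drop is expected. The step from compound 2 to compound 4 is expected to be a number 89 percentage points lower from compound 2 to compound 4 (beyond the scatter). Compound 4 is therefore estimated to give 20% in this assay. For compound 4 the expected range runs from 5% to 50%, the width reflecting that the precedent rests on a single pair.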

Compound 4, largest response reached (reported as percent of maximum), in percent of the reference or control that the assay uses: 26.3%
Estimate against measurement, compound 4: 6.3 percentage points below; the range from low to high includes it.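

On the core of compound 2, putting hydrogen in place of tert-butyl on a saturated chain carbon bound to a carbonyl carbon again removes most of the response in this assay, with a number 82.7 percentage points lower from compound 2 to compound 4 (beyond the scatter). Set beside the earlier step on the core of compound 1, the size of the loss does not separate the two cores: the same change on two cores in this assay, a number 91.9 percentage points lower (beyond the scatter) from compound 1 to compound 3 and a number 82.7 percentage points lower (beyond the scatter) from compound 2 to compound 4, 9.2 percentage points apart, within the scatter of two such steps Within this series, the loss therefore carries over from one core to the other, but this rests on just two pairs, so it shows neither that the same would hold on any further core nor why the response falls.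

The compounds shown leave open how the response changes between the two extremes at this carbon, for instance with a methyl, an isopropyl or a cyclopropyl group in place of the tert-butyl, and whether the same loss would appear with each of those groups on both cores. They also leave open whether the carboxylic acid, present in all four compounds, could give way to an amide or a tetrazole, and how a shorter or longer chain between the two ether oxygens would fare.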